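This account rests on a few compounds, and the source may have more. Where it says the series, first, only, none or still open, it means among the compounds named here.

Among the compounds with values here, compound 2 `COc1ccccc1/C=C/C(=O)Nc1ccc2ncnc(Nc3cccc(Br)c3)c2c1` is one of only two measured members of this set, the other being compound 1 `COc1ccc(/C=C/C(=O)Nc2ccc3ncnc(Nc4cccc(Br)c4)c3c2)cc1`. In a functional assay on B16-F10 cells (Mus musculus) for inhibition, read by MTT assay, with a stated time of 48 h (on this read-out higher numbers stand for weaker inhibition and lower numbers for stronger inhibition), compound 1 gives 1.24 ug/mL, and in this assay compound 2 gives 1.28 ug/mL; the step of a 1.0-fold higher number from compound 1 to compound 2 (0.01 log units; within the scatter) leaves the two level with each other. On the numbers shown compound 2 therefore stands on a par with compound 1, with no other measured point to place it against.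

Compound 3 `O=C(/C=C/c1cccs1)Nc1ccc2ncnc(Nc3cccc(Br)c3)c2c1` differs from compound 2 in one place: thiophen-2-yl in place of 2-methoxyphenyl on a double-bonded chain carbon bound to a double-bonded chain carbon. Within the data shown here, no measured step touches the identity of the aromatic ring on this chain carbon. Among the measured compounds shown here, the single step available, a 1.0-fold higher number from compound 1 to compound 2 (0.01 log units; within the scatter), shifts only the position of a methoxy group on that ring and stays within the scatter, so it shows that a small change at this end of the chain left this assay unmoved, but it says nothing about exchanging the ring itself. With that gap in the data, the expectation is no step beyond the scatter, stated with a wide range. Compound 3 is estimated at 1.5 ug/mL in this assay, between 0.6 ug/mL and 4 ug/mL, which corresponds to an expected step of a 1.2-fold higher number from compound 2 to compound 3 (0.07 log units; within the scatter).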

Compound 3, half-maximal inhibitory concentration: 2.51 ug/mL
For compound 3 the middle estimate is 1.7-fold (0.22 log units) below the measured one, and the stated range covers the measured number.
By their numbers in this assay, from the lowest: compounds 1, 2 and 3 (each within the scatter of the next, the first and the last beyond it).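

In this assay, within the data shown here, these results are the first to cover an exchange of the ring itself on this chain carbon, rather than a shift of the methoxy group on it. Thiophen-2-yl in place of 2-methoxyphenyl gives a 2.0-fold higher number from compound 2 to compound 3 (0.29 log units; within the scatter), whereas thiophen-2-yl in place of 4-methoxyphenyl gives a 2.0-fold higher number from compound 1 to compound 3 (0.31 log units; beyond the scatter), so the same entering group reads differently according to the comparison, with only the second step clearing the scatter and that one modest. Across these three compounds, a five-membered aromatic ring with one hetero atom can therefore stand in for a methoxy-bearing six-membered carbon ring at this place with no large change in the read-out, and nothing available here accounts for the modest step.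

Still open, from the compounds shown here alone, is how this chain carbon responds to groups further from those compared here, such as a phenyl ring carrying an amine or a carboxylic acid, or a saturated cyclohexyl ring. Also unresolved is whether the thiophen-2-yl result holds when the 2-(thiophen-2-yl)ethenyl end is kept and the rest of the shared core is changed.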